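Replacing benzoyl with 3,4-dichlorophenyl in compound 3

The compounds below may be only part of what the source reports. "The series", "measured", "known", "first", "only" and "open" are said of these compounds alone.

Measured in an ADME assay on HEK293 cells (Homo sapiens) for cytotoxicity, with a stated time of 72 h; a higher number here means that more compound is needed for the effect, a lower number that less compound is needed:
- compound 1 `C=C[C@@](C)(/C=C/c1ccc(OC)cc1)CCC=C(C)C`: > 36600 nM, a limit
- compound 2 `C=C[C@@](C)(/C=C/c1ccc(O)cc1)CCC1OC1(C)C`: > 36600 nM, a limit
- compound 3 `C=C[C@@](C)(/C=C/c1ccc(O)c(/C=C/C(=O)c2ccccc2)c1)CCC=C(C)C`: > 7410 nM, a limit

None of the three compounds has given an actual number. Compound 3 stands at the limit of > 7410 nM in this assay, at which 1 of the 3 values shown sits. The other two compounds stand at the limit of > 36600 nM in this assay, at which 2 of the 3 values shown sit.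

Compound 4 `C=C[C@@](C)(/C=C/c1ccc(O)c(/C=C/c2ccc(Cl)c(Cl)c2)c1)CCC=C(C)C` keeps the core of compound 3 and carries 3,4-dichlorophenyl in place of benzoyl on a double-bonded chain carbon bound to a double-bonded chain carbon. Going by the values given here, no two measured compounds differ in one place, so no measured step bears directly on this change.

The expectation rests on compound 3 at > 7410 nM, which is a limit. No change beyond the scatter is expected in this assay, in either direction, and the expected step is a step that the limit leaves unreadable from compound 3 to compound 4. Compound 4 is estimated at 10000 nM, with an expected range from 3000 nM to 36000 nM. The assay may well report it only as a limit.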

Compound 4, half-maximal effective concentration: > 36600 nM
Compound 4 gave a limit, no number (the forecaster's own chance of this, stated with the estimate: 70%); at least 3.6-fold (0.56 log units) between middle value and limit.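

In this assay compound 3 and compound 4 each gave only a limit, and the step between them cannot be read. The compounds shown leave open whether 3,4-dichlorophenyl in place of benzoyl changes the concentration needed for the effect at all, and in which direction.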